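The source may report more compounds than this note shows. Statements on the series, on what has been measured and on what is new or still open speak of the compounds shown alone.

Measured so far in a functional assay on MCF7 cells (Homo sapiens) for inhibition, with a stated time of 48 h; on this read-out lower numbers stand for stronger inhibition and higher numbers for weaker inhibition:
- compound 1 `COc1cc(Sc2c[nH]c3ccccc23)cc(OC)c1OC` gives 34 nM
- compound 2 `COc1cc(Sc2c[nH]c3ccc(Cl)cc23)cc(OC)c1OC` gives 77 nM
- compound 3 `COc1ccc2[nH]cc(Sc3cc(OC)c(OC)c(OC)c3)c2c1` gives 22 nM

Compound 3 shares the low end of these numbers with compound 1: a 1.5-fold lower number from compound 1 to compound 3 (0.19 log units; within the scatter) stands against a 3.5-fold lower number from compound 2 to compound 3 (0.54 log units; beyond the scatter) in this small set. Compound 4 `CCOc1ccc2[nH]cc(Sc3cc(OC)c(OC)c(OC)c3)c2c1` carries methyl in place of hydrogen on a saturated chain carbon bound to an oxygen on an aromatic ring and so turns methoxy to ethoxy. Going by the values given here, no measured step makes this exact change. The closest evidence is a 1.5-fold lower number from compound 1 to compound 3 (0.19 log units; within the scatter) for methoxy in place of hydrogen, alongside the modest 2.3-fold higher number from compound 1 to compound 2 (0.36 log units; beyond the scatter) for chloro in place of hydrogen. In this assay no step beyond the scatter is expected, with a slight lean toward a higher number. The estimated step is a 1.4-fold higher number from compound 3 to compound 4 (0.13 log units; within the scatter) as a working figure. Compound 4 is estimated at 30 nM with an expected range from 12 nM to 75 nM on present data.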

Compound 4, half-maximal inhibitory concentration: 16 nM
Compound 4: middle estimate off by 1.9-fold (0.27 log units), on the high side, and the stated range covers the measured number.
By their numbers in this assay, from the lowest: compounds 4, 3 and 1 (each within the scatter of the next, the first and the last beyond it); then compound 2.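

In this assay, the position takes methoxy to ethoxy without a readable change (a 1.4-fold lower number from compound 3 to compound 4 (0.14 log units; within the scatter)). Ethoxy in place of hydrogen does give a step beyond the scatter (a 2.1-fold lower number from compound 1 to compound 4 (0.33 log units; beyond the scatter)), which methoxy in place of hydrogen did not, and ethoxy in place of chloro gives the largest step in the set (a 4.8-fold lower number from compound 2 to compound 4 (0.68 log units; beyond the scatter)). No measured evidence on the cause of these steps is available here.

Going by these compounds, whether a longer chain, or an amine or carboxylic acid in place of ethoxy, keeps numbers in this range remains open.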